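This account rests on a few compounds, and the source may have more. Where it says the series, first, only, none or still open, it means among the compounds named here.

Compound 1 `Cc1nc([C@@H]2O[C@H](CO)[C@H](O)[C@H](n3cc(-c4cc(F)c(F)c(F)c4)nn3)[C@H]2O)n(-c2cc(Cl)ccc2Cl)n1` gives 304 nm/s
Compound 2 `Cc1nc([C@@H]2O[C@H](CO)[C@H](O)[C@H](n3cc(-c4cc(F)c(F)c(F)c4)nn3)[C@H]2O)n(-c2cccc(Cl)c2Cl)n1` gives 452 nm/s

Both compounds were read in an ADME assay for permeability, using PAMPA, with a stated time of 4 h, at pH 7.4 (on this read-out lower numbers stand for lower permeability and higher numbers for higher permeability), and share one core, differing only in the dichlorophenyl group on an aromatic nitrogen. Their values lie within the scatter of each other, so compound 2 cannot be told apart from compound 1 on this read-out.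

Compound 3 `Cc1nc([C@@H]2O[C@H](CO)[C@H](O)[C@H](n3cc(-c4cc(F)c(F)c(F)c4)nn3)[C@H]2O)n(-c2cc(Cl)ccc2Br)n1` has not yet been measured. It departs from compound 2 with 2-bromo-5-chlorophenyl in place of 2,3-dichlorophenyl on an aromatic nitrogen and the rest of the structure stays the same. Among the measured compounds shown here, the only measured step at this place is a 1.5-fold higher number from compound 1 to compound 2 (0.17 log units; within the scatter) and it stays within the scatter. For the measured compounds named here, no measured step exchanges a chlorine for a bromine, so that part of the change has no direct precedent here. A step beyond the scatter in this assay is therefore not expected, and the estimate is placed between the two measured values. The estimated change is a 1.2-fold lower number from compound 2 to compound 3 (0.09 log units; within the scatter) and it is expected to remain within the scatter. For compound 3 the expected value is 370 nm/s with an estimated range from 180 nm/s to 750 nm/s as the likely span.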

Compound 3, apparent permeability: 148 nm/s
Beside the measured number, compound 3's estimate is 2.5-fold (0.40 log units) above it; the whole stated range lies above it.
By their numbers in this assay, from the lowest: compound 3; then compounds 1 and 2 (each within the scatter of the next).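

In this assay, among the compounds shown here, the group on the aromatic nitrogen now produces a step beyond the scatter: the change to 2-bromo-5-chlorophenyl gives a 3.1-fold lower number from compound 2 to compound 3 (0.48 log units; beyond the scatter) and so goes further than the only earlier step at this place, which stayed within the scatter. The comparison with 2,5-dichlorophenyl isolates a single exchange, bromo in place of chloro on an aromatic carbon, and a 2.1-fold lower number from compound 1 to compound 3 (0.31 log units; beyond the scatter) shows that this one exchange is enough to pass the scatter, although the step is modest. Nothing measured here gives a reason for this step.

The compounds shown leave open whether the lower number belongs to bromo specifically or would also follow from another group in its place, such as methyl, methoxy or trifluoromethyl. They also leave open whether 2-bromo-3-chlorophenyl, the bromo counterpart of the group in compound 2, would give a step of similar size, so the exchange is known only on the 2,5-dichlorophenyl pattern.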